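This account rests on a few compounds, and the source may have more. Where it says the series, first, only, none or still open, it means among the compounds named here.

In an ADME assay on PANC-1 cells (Homo sapiens) for cytotoxicity, read by sulforhodamine B assay, with a stated time of 48 h, tested at 10 uM (on this read-out lower numbers stand for less inhibition and higher numbers for more inhibition at the one concentration tested (going by the name of the read-out)), compound 2 `COc1nc2ccc(Br)cc2cc1C(c1ccccc1)n1cc(-c2ccccc2C(F)(F)F)nn1` gives 11.4%. Among the measured compounds shown here, the only other number comes from compound 1 `CCCCCc1cn(C(c2ccccc2)c2cc3cc(Br)ccc3nc2OC)nn1`, which gives 5.07% in this assay; the two lie within the scatter of each other. Compound 3 `COc1nc2ccc(Br)cc2cc1C(c1ccccc1)n1cc(CCCCCO)nn1` differs from compound 2 by 5-hydroxypentyl in place of 2-(trifluoromethyl)phenyl on an aromatic carbon. For the measured compounds named here, the one measured step, a number 6.3 percentage points higher from compound 1 to compound 2 (within the scatter), swapped a group at this same place and left the inhibition essentially unchanged, so a further swap at that place is expected to stay within the scatter too, giving an expected step of a number 3.4 percentage points lower from compound 2 to compound 3 (within the scatter). Compound 3 is therefore estimated at 8%, in the range 0% to 20%.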

Compound 3, a percentage reported as inhibition, at one concentration (the size of the read-out at that concentration, not a potency): 19.6%
Beside the measured number, compound 3's estimate is 11.6 percentage points below it; low and high end bracket the measured number.
By their numbers in this assay, from the lowest: compounds 1, 2 and 3 (each within the scatter of the next, the first and the last beyond it).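

Swapping the ring-bearing group for an open chain at this carbon of the five-membered aromatic ring changes little, with a number 8.2 percentage points higher from compound 2 to compound 3 (within the scatter) in this assay. Among the compounds shown here, the clearer change is the hydroxy in place of hydrogen on the chain, which gives a number 14.5 percentage points higher from compound 1 to compound 3 (beyond the scatter) and is the first step here beyond the scatter, though a modest one. No available evidence explains this step.

Still open, going by these compounds, is whether an amine or a carboxylic acid in place of that hydroxy would give a similar number. On these data alone, a longer chain carrying the hydroxy is equally open.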